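Phenyl in place of cyanophenyl on the triazole aryl

This account rests on a few compounds, and the source may have more. Where it says the series, first, only, none or still open, it means among the compounds named here.

Measured compounds:
Compound 1, `COc1ccccc1-n1cc(COc2c(/C=C\C(=O)O)ccc(OC)c2CC=C(C)C)nn1`, gives 32600 nM in a functional assay on A-431 cells (Homo sapiens) for cytotoxicity, read by MTT assay, with a stated time of 24 h; a higher number here means a weaker inhibitor, a lower number a stronger inhibitor.
Compound 2, `COc1ccc(/C=C\C(=O)O)c(OCc2cn(-c3ccc(NC(=O)c4ccccc4)cc3)nn2)c1CC=C(C)C`, gives 21200 nM in this assay.
Compound 3, `COc1ccc(/C=C\C(=O)O)c(OCc2cn(-c3cccc(C#N)c3)nn2)c1CC=C(C)C`, gives 22900 nM in this assay.

Compound 3 stands second highest of the three numbers in this assay. Its nearest neighbour is compound 2, and the gap between them is within the scatter; its furthest neighbour is compound 1, and that gap too is within the scatter. Going by the values given here, the only step between compounds that differ in one place, a 1.4-fold lower number from compound 1 to compound 3 (0.15 log units; within the scatter), is likewise within the scatter.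

Compound 4, `COc1ccc(/C=C\C(=O)O)c(OCc2cn(-c3ccccc3)nn2)c1CC=C(C)C`, differs from compound 3 by hydrogen in place of cyano on an aromatic carbon. The step from compound 1 to compound 3 bears on this change, as it also alters the aryl group on the aromatic nitrogen, and compound 2 shows that a further aryl variation still gives a number within the scatter of compound 3. Among the compounds with values here, nothing among the measured compounds indicates a shift beyond the scatter for this change. For compound 4 the step is therefore expected to be a 1.1-fold higher number from compound 3 to compound 4 (0.04 log units; within the scatter). The estimate for compound 4 in this assay is 25000 nM, with a range from 10000 nM to 60000 nM.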

Compound 4, half-maximal inhibitory concentration: 21200 nM
Compound 4: middle estimate off by 1.2-fold (0.07 log units), on the high side; the range from low to high includes it.
By their numbers in this assay, from the lowest: compounds 2, 4, 3 and 1 (each within the scatter of the next).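

Going by these compounds alone, compound 4 gives this aryl group on the aromatic nitrogen an unsubstituted phenyl reference, which the earlier compounds lacked, since their one step compared two substituted aryl groups. In this assay each substituent can now be set directly against hydrogen, and the nitrile (a 1.1-fold lower number from compound 3 to compound 4 (0.03 log units; within the scatter)), the benzamido group (no change at the digits printed from compound 2 to compound 4 (within the scatter)) and the methoxy group (a 1.5-fold lower number from compound 1 to compound 4 (0.19 log units; within the scatter)) all give steps within the scatter, so none of the three separates from hydrogen in this cytotoxicity read-out, despite the large difference in size between the nitrile and the benzamido group. Nothing measured here explains why these replacements leave the number in place.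

The compounds shown leave open whether a substituent of another kind on this phenyl ring, such as an amine, a hydroxyl group or a carboxylic acid, would give a step beyond the scatter, and whether an alkyl chain in place of the aryl group would do so. All four compounds also share the same core, so they say nothing about how the number responds to a change there, such as an ester or amide in place of its carboxylic acid.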